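The source may report more compounds than this note shows. Statements on the series, on what has been measured and on what is new or still open speak of the compounds shown alone.

Measured in an ADME assay on Vero cells (Chlorocebus sabaeus) for cytotoxicity; on this read-out lower numbers stand for higher toxicity in this test and higher numbers for lower toxicity in this test:

Compound 1 `COc1ccc(-c2nc3cc(C(F)(F)F)ccc3[nH]2)c(OC)c1OC` gives 70000 nM.
Compound 2 `Oc1ccc(-c2nc3cc(C(F)(F)F)ccc3[nH]2)cc1` gives only a limit, > 100000 nM.
Compound 3 `Cn1c(-c2ccc([N+](=O)[O-])cc2)nc2cc(C(F)(F)F)ccc21` gives only a limit, > 100000 nM.

For the measured compounds named here, compound 2 therefore stands at the limit of > 100000 nM in this assay, at which 2 of the 3 values shown sit; compound 1 alone returns a number, and no step between measured compounds is available.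

Compound 4 `CCC(=O)Nc1ccc(-c2nc3cc(C(F)(F)F)ccc3[nH]2)cc1` is not yet measured. It differs from compound 2 as follows: propanoylamino in place of hydroxy on an aromatic carbon.

Going by the values given here, with no measured step to lean on, the expectation for this assay is a step from compound 2 to compound 4 of no size beyond the usual scatter, most likely again a limit: a number no higher from compound 2 to compound 4 (the limit leaves the size open). Compound 4 is accordingly estimated at 100000 nM, within a range from 50000 nM to 200000 nM.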

Compound 4, half-maximal cytotoxic concentration: > 100000 nM
Compound 4: only a limit was reported; the forecaster's own chance of this, stated with the estimate: 65%; the middle value lies on the limit itself.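

In this assay, for the compounds shown here, compound 2 and compound 4 each return only a limit, so no step between them can be read. The compounds shown leave open what size of step, if any, propanoylamino in place of hydroxy produces.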